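Benzoyl in place of benzyloxycarbonyl on the shared core

This account rests on a few compounds, and the source may have more. Where it says the series, first, only, none or still open, it means among the compounds named here.

In an ADME assay on L929 cells (Mus musculus) for cytotoxicity, read by resazurin assay, with a stated time of 48 h (on this read-out higher numbers stand for lower toxicity in this test and lower numbers for higher toxicity in this test), compound 1 (`CCOCCCn1c2ccc([N+](=O)[O-])cc2c(=O)n1Cc1ccccc1`) gives 170000 nM. For the measured compounds named here, compound 2 (`O=C(OCc1ccccc1)n1c2ccc([N+](=O)[O-])cc2c(=O)n1Cc1ccccc1`) gives 86100 nM, and these two values lie within the scatter of each other, so compound 2 has only this one neighbour and no separated rank. Compound 3 (`O=C(c1ccccc1)n1c2ccc([N+](=O)[O-])cc2c(=O)n1Cc1ccccc1`) comes from compound 2 by phenyl in place of benzyloxy on a carbonyl carbon, or benzyloxycarbonyl to benzoyl. Going by the values given here, no measured step covers this exact exchange. Among the compounds with values here, because a 2.0-fold lower number from compound 1 to compound 2 (0.30 log units; within the scatter) is the only step available, and it also concerns the group on an aromatic nitrogen, no step beyond the scatter is expected in this assay. The step expected is a 1.1-fold lower number from compound 2 to compound 3 (0.03 log units; within the scatter). For compound 3 the estimated value is 80000 nM, with an expected range of 30000 nM to 200000 nM.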

Compound 3, concentration lethal to 50% of the cells: 146000 nM
Compound 3: the middle estimate sits 1.8-fold (0.26 log units) below what was measured; the measured number falls inside the stated range.
By their numbers in this assay, from the lowest: compounds 2, 3 and 1 (each within the scatter of the next).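

In this assay phenyl in place of benzyloxy on a carbonyl carbon gives a 1.7-fold higher number from compound 2 to compound 3 (0.23 log units; within the scatter) and does not separate the two compounds, so the benzyloxy group can be exchanged for phenyl here without a readable step. Benzoyl in place of 3-ethoxypropyl on the aromatic nitrogen gives a 1.2-fold lower number from compound 1 to compound 3 (0.07 log units; within the scatter) and is likewise not separated in this assay, so 3-ethoxypropyl, benzyloxycarbonyl and benzoyl at this position form a chain of values, each within the scatter of the next. Nothing measured on these compounds offers a reason for these small differences.

As far as these compounds go, whether an amine or a carboxylic acid carried on this aromatic nitrogen would give a step beyond the scatter remains open. Also open, from the compounds shown here alone, is whether replacing the benzyl group on the other ring nitrogen of the shared core would do so.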